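The source may report more compounds than this note shows. Statements on the series, on what has been measured and on what is new or still open speak of the compounds shown alone.

Of the compounds shown here, two share one core and have been tested in a functional assay on HepG2 cells (Homo sapiens) for antiproliferative activity, read by MTT assay, with a stated time of 48 h; on this read-out higher numbers stand for weaker inhibition and lower numbers for stronger inhibition. Compound 1, with the structure `COc1ccc(-c2ccc3c(c2)C(=O)C(=O)N3Cc2ccccc2OC)cc1`, gives 130 nM in this assay. Compound 2, with the structure `COc1ccc(CN2C(=O)C(=O)c3cc(-c4cccc(OC)c4)ccc32)cc1`, gives 1890 nM in this assay, the higher of the two numbers, meaning weaker inhibition of cell growth; its gap to compound 1 lies beyond the scatter of repeated measurements.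

Compound 3, with the structure `COc1ccc(CN2C(=O)C(=O)c3cc(-c4ccncc4)ccc32)cc1`, has not yet been measured. It differs from compound 2 in one place: pyridin-4-yl in place of 3-methoxyphenyl on an aromatic carbon. The new group sits on an aromatic carbon of a six-membered aromatic ring of carbon only, part of a fused or bridged system of two rings, where compound 2 carries the 3-methoxyphenyl group.

Going by the values given here, no pair of measured compounds shows what this exchange does, so the expectation rests only on the weak inhibition seen for compound 2. The step in this assay is expected to be small, a 1.3-fold lower number from compound 2 to compound 3 (0.10 log units; within the scatter), and may stay within the scatter. Compound 3 is accordingly estimated to give 1500 nM in this assay, most likely between 500 nM and 5000 nM.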

Compound 3, half-maximal inhibitory concentration: > 10000 nM
Compound 3: a limit, no number; the forecaster's own chance of this, stated with the estimate: 10%; middle value at least 6.6-fold (0.82 log units) away from the limit.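

In this assay, going by these compounds alone, replacing 3-methoxyphenyl with pyridin-4-yl on this aromatic carbon gives an at least 5.2-fold higher number from compound 2 to compound 3 (0.72 log units; beyond the scatter), so inhibition of cell growth here depends strongly on which six-membered aromatic ring the position carries, a dependence that the earlier compounds could not reveal. Compound 3 gives a limit of the assay, not a number: the limit of > 10000 nM in this assay, at which 1 of the 3 values shown sits. The two groups have the same counts of 0 hydrogen-bond donors and 1 hydrogen-bond acceptor, and neither carries a net charge, so these counts do not separate them; they differ in that a ring of carbon only with 8 heavy atoms in the group gives way to a ring with 1 hetero atom and 6 heavy atoms in the group.

The compounds shown leave open whether the weaker inhibition follows from the entry of the ring nitrogen or from the loss of the methoxy group, as both changes occur in this single exchange. A plain phenyl group at this position would keep the all-carbon ring without the methoxy group, and pyridin-3-yl would place the ring nitrogen differently, so each could help separate these two changes.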